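A few compounds are considered here, and "the series" means these few. Any claim that something is new, unique, unknown or untested is made for them only; others in the source may bear on it.

Compound 1 `N#Cc1ccc(Nc2nc(Oc3ccc(Cl)cc3)c3ccccc3n2)cc1` gives 198000 nM in an ADME assay on MT4 cells (Homo sapiens) for cytotoxicity, read by MTT assay, with a stated time of 4 days; on this read-out higher numbers stand for lower toxicity in this test and lower numbers for higher toxicity in this test. Compound 2 `CCCOc1cc(C#N)cc(OC)c1Oc1nc(Nc2ccc(C#N)cc2)nc2ccccc12` gives 5200 nM, a number beyond the scatter from that of compound 1, whereas compound 3 `CCCOc1cc(C#N)cc(OCC)c1Oc1nc(Nc2ccc(C#N)cc2)nc2ccccc12` gives 123000 nM, which lies within the scatter of compound 1. Among the compounds with values here, the only measured step, a 24-fold higher number from compound 2 to compound 3 (1.37 log units; beyond the scatter), concerns a saturated chain carbon bound to an oxygen on an aromatic ring and not a halogen, so it carries little over to the change at hand. Compound 4 `N#Cc1ccc(Nc2nc(Oc3ccc(F)cc3)c3ccccc3n2)cc1` differs from compound 1 by fluoro in place of chloro on an aromatic carbon. Within the data shown here, with no measured step bearing on fluoro in place of chloro, compound 4 is expected to show a 1.0-fold higher number from compound 1 to compound 4 (0.00 log units; within the scatter), a step not beyond the scatter. Compound 4 is therefore estimated at 200000 nM, with a range from 80000 nM to 450000 nM.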

Compound 4, half-maximal cytotoxic concentration: > 351000 nM
Compound 4 was reported as a limit; the forecaster's own chance of this, stated with the estimate: 30%; middle value at least 1.7-fold (0.24 log units) away from the limit.
By their numbers in this assay, from the lowest: compound 2; then compounds 3 and 1 (each within the scatter of the next). At a limit, above all of these: compound 4.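

Fluoro in place of chloro on this aromatic carbon gives an at least 1.7-fold higher number from compound 1 to compound 4 (0.24 log units; that floor lies within the scatter) in this assay, the first reading of any change at this halogen. For compound 4, > 351000 nM is a limit of the assay and not a number. Going by these compounds, the true size of the step therefore stays unknown, but the swap brought no fall in the number, which would have pointed to higher toxicity in this test.

Still open, on these data alone, is how a bromo, a methoxy or an amine at this same place would read.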